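A few compounds are considered here, and "the series" means these few. Any claim that something is new, unique, unknown or untested is made for them only; others in the source may bear on it.

In a functional assay on MCF7 cells (Homo sapiens) for inhibition, read by colorimetric assay and MTT assay, with a stated time of 72 h (a lower number here means a stronger inhibitor, a higher number a weaker inhibitor), compound 2 `C=CCCCCOc1ccccc1-c1cnc(OCCCCC=C)n1C` gives 5000 nM, level with compound 3 `C=CCCCCOc1ncc(-c2ccccc2OC)n1C` at 5000 nM. These two share the lowest number of the three measured, while compound 1 `Cn1c2cnc1OCCCCCCCCCCOc1ccccc1-2` reads higher at 24000 nM. Compound 4 `C=CCCCCOc1ccccc1-c1cnc(OCCOCC=C)n1C` keeps the shared core and alters one chain: allyloxy in place of but-3-en-1-yl on a saturated chain carbon, two bonds along the chain from an oxygen on an aromatic ring, with allyloxy in place of but-3-en-1-yl on a saturated chain carbon, two bonds along the chain from an oxygen on an aromatic ring. Within the data shown here, the one measured step bearing on this chain is no change at the digits printed from compound 2 to compound 3 (within the scatter), with hydrogen in place of pent-4-en-1-yl. No step beyond the scatter is therefore expected in this assay. The expected step is a 1.2-fold higher number from compound 2 to compound 4 (0.08 log units; within the scatter). For compound 4 the estimate is 6000 nM, with an expected range of 2500 nM to 14000 nM.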

Compound 4, half-maximal inhibitory concentration: 32000 nM
Beside the measured number, compound 4's estimate is 5.3-fold (0.73 log units) below it; measured number above the stated range.
By their numbers in this assay, from the lowest: compounds 2 and 3 (each within the scatter of the next); then compounds 1 and 4 (each within the scatter of the next).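

In this assay, the chain on the shared core does not tolerate this change silently: allyloxy in place of but-3-en-1-yl, on a saturated chain carbon two bonds along the chain from an oxygen on an aromatic ring, gives a clear loss (a 6.4-fold higher number from compound 2 to compound 4 (0.81 log units; beyond the scatter)). The earlier step (no change at the digits printed from compound 2 to compound 3 (within the scatter)) changed the other chain and showed no such sensitivity. Here, an oxygen entering the chain is enough to separate the two compounds.

As far as these compounds go, whether an amine or a longer chain at this place would be tolerated remains open. Nothing available explains the step.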